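Compound 1 and a carboxylic acid chain on the ring

The source may report more compounds than this note shows. Statements on the series, on what has been measured and on what is new or still open speak of the compounds shown alone.

Measured in an ADME assay on microsomes from liver (Mus musculus) for metabolic stability, read by LC-MS, using NADPH, with a stated time of 60 min, tested at 1 uM; on this read-out higher numbers stand for a longer-lived compound and lower numbers for a shorter-lived compound:
compound 1 `O=S(=O)(c1cccc(C(F)(F)F)c1)N1CCc2ccc(-c3cc(F)cc(OC(F)F)c3)cc21` gives 0.19 h
compound 2 `O=C(O)CC1Cc2ccc(-c3cc(F)cc(OC(F)F)c3)cc2N1S(=O)(=O)c1cccc(C(F)(F)F)c1` gives 1.88 h
compound 3 `O=C(O)CCCC1Cc2ccc(-c3cc(F)cc(OC(F)F)c3)cc2N1S(=O)(=O)c1cccc(C(F)(F)F)c1` gives 1.56 h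
Not yet measured: compound 4 `O=C(O)CCC1CN(S(=O)(=O)c2cccc(C(F)(F)F)c2)c2cc(-c3cc(F)cc(OC(F)F)c3)ccc21`

Compound 1 stands lowest of the three, and both other compounds lie beyond the scatter above it. Compound 4 follows from compound 1 with 2-carboxyethyl in place of hydrogen on a saturated ring carbon. Among the measured compounds shown here, two measured steps bear on this change, and both add a carboxylic acid chain to compound 1. With carboxymethyl the result is a 9.9-fold higher number from compound 1 to compound 2 (1.00 log units; beyond the scatter), and with 3-carboxypropyl it is an 8.2-fold higher number from compound 1 to compound 3 (0.91 log units; beyond the scatter). The two chains differ little from each other, as a 1.2-fold lower number from compound 2 to compound 3 (0.08 log units; within the scatter) shows, and this step lies within the scatter. The 2-carboxyethyl chain of compound 4 falls between these two chains by name. However, it sits two ring bonds from the ring nitrogen, which is not the carbon that carries the chains of compound 2 and compound 3, and no measured compound tests that place. A rise in this assay is therefore expected, of similar size or somewhat smaller. The expected step is a 6.8-fold higher number from compound 1 to compound 4 (0.84 log units; beyond the scatter). The half-life estimated for compound 4 is 1.3 h, with an expected range from 0.6 h to 2.8 h.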

Compound 4, half-life: 0.408 h
Compound 4: middle estimate off by 3.2-fold (0.50 log units), on the high side, outside the stated range (below it).
By their numbers in this assay, from the lowest: compound 1; then compound 4; then compounds 3 and 2 (each within the scatter of the next).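

In this assay, a 2-carboxyethyl chain on this saturated ring carbon, two ring bonds from the ring nitrogen, still lengthens the half-life, with a 2.1-fold higher number from compound 1 to compound 4 (0.33 log units; beyond the scatter). This rise is clearly smaller than those seen when the other chains were added to compound 1, a 9.9-fold higher number from compound 1 to compound 2 (1.00 log units; beyond the scatter) and an 8.2-fold higher number from compound 1 to compound 3 (0.91 log units; beyond the scatter), so the size of those rises does not carry over to compound 4, although the direction does. Nothing given here accounts for the smaller step, and compound 4 differs from compound 2 and compound 3 both in its chain and in the carbon that carries it.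

What the compounds shown leave open is how much of the gap belongs to the place and how much to the chain, as neither carboxymethyl nor 3-carboxypropyl appears on this carbon, nor 2-carboxyethyl on the carbon that carries the chains of compound 2 and compound 3. Among the compounds shown here, they also leave open whether the acid itself matters here, since no compound carries an amide, an alcohol or a plain alkyl chain on either carbon.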